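Swapping One Aryl Group on a Shared Core

A few compounds are considered here, and "the series" means these few. Any claim that something is new, unique, unknown or untested is made for them only; others in the source may bear on it.

Of the compounds shown here, three have been measured in an ADME assay on microsomes from liver (Rattus norvegicus) for metabolic stability, read by LC-MS, using NADPH, with a stated time of 10 min, tested at 0.1 uM (a lower number here means slower removal, a higher number faster removal of the compound), so far. Compound 1 (`COc1ccccc1N1C(=O)CSC1c1cc(F)cc(C(=O)NCCCCc2ccccc2)c1`) gives 3260 mL.min-1.g-1 in this test, compound 2 (`COc1ccc(F)cc1N1C(=O)CSC1c1cccc(C(=O)NCCCCc2ccccc2)c1`) gives 2300 mL.min-1.g-1 and compound 3 (`Cc1ccnc(N2C(=O)CSC2c2cccc(C(=O)NCCCCn3cccn3)c2)c1`) gives 1020 mL.min-1.g-1 there. Compound 2 therefore lies within the scatter of compound 1, while compound 3 stands lower than compound 2, beyond the scatter.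

Compound 4 (`CC(F)(F)c1cccc(N2C(=O)CSC2c2cccc(C(=O)NCCCCc3ccccc3)c2)c1`) departs from compound 2 on an amide-type nitrogen in a ring: a group of 10 heavy atoms (8 carbon, 2 fluorine; one six-membered aromatic ring of carbon only) in place of a group of 9 heavy atoms (7 carbon, 1 oxygen, 1 fluorine; one six-membered aromatic ring of carbon only), on an amide-type nitrogen in a ring with the 5-fluoro-2-methoxyphenyl group leaving. Among the measured compounds shown here, no measured pair isolates a change at a single place, so the expectation is tentative. It leans on compound 2 at 2300 mL.min-1.g-1 and on compound 1 at 3260 mL.min-1.g-1 as the closest measured neighbours. The estimated step is a 1.2-fold higher number from compound 2 to compound 4 (0.09 log units; within the scatter) and is expected to be a small rise inside the scatter. Compound 4 is expected to show an intrinsic clearance of about 2800 mL.min-1.g-1 with an estimated range of 1400 mL.min-1.g-1 to 5500 mL.min-1.g-1 in this assay when measured.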

Compound 4, intrinsic clearance in microsomes: 2320 mL.min-1.g-1
Estimate against measurement, compound 4: 1.2-fold (0.08 log units) above; the measured number falls inside the stated range.
By their numbers in this assay, from the lowest: compound 3; then compounds 2, 4 and 1 (each within the scatter of the next).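

Among the compounds shown here, this is the first pair that differs in one place only, so it isolates the group on an amide-type nitrogen in a ring: when the 5-fluoro-2-methoxyphenyl group is exchanged, this assay gives a 1.0-fold higher number from compound 2 to compound 4 (0.00 log units; within the scatter). At this position, the one hydrogen-bond acceptor counted on the leaving group can go, and the number of heavy atoms can differ, without a step beyond the scatter. Nothing measured here offers an explanation for this result.

One pair cannot tell whether other groups at this position would also leave the read-out within the scatter, such as a phenyl ring bearing an amine or a carboxylic acid. On these data alone, it also remains open whether the same exchange would give a similar step on the chain carried by compound 3.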